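Tetrazole for nitrile on a shared 5-lipoxygenase scaffold

The source may report more compounds than this note shows. Statements on the series, on what has been measured and on what is new or still open speak of the compounds shown alone.

The measured compounds in an assay on isolated protein with Polyunsaturated fatty acid 5-lipoxygenase (Homo sapiens) as the target (on this read-out higher numbers stand for weaker inhibition and lower numbers for stronger inhibition), are:
compound 1 `COCc1cc(-c2ccccc2)c2ccc(OCc3cccc(C4(O)CCOCC4)c3)cc2c1`, giving 160 nM;
compound 2 `CC(=O)c1cc(-c2ccccc2)c2ccc(OCc3cccc(C4(O)CCOCC4)c3)cc2c1`, giving 130 nM;
compound 3 `N#Cc1cc(-c2ccccc2)c2ccc(OCc3cccc(C4(O)CCOCC4)c3)cc2c1`, giving 120 nM.

Compound 3 has the lowest of the three numbers, but its nearest neighbour compound 2 and its furthest neighbour compound 1 both sit within the scatter, so the three cannot be ordered. Compound 4 `OC1(c2cccc(COc3ccc4c(-c5ccccc5)cc(-c5nn[nH]n5)cc4c3)c2)CCOCC1` differs from compound 3 in one place: 2H-tetrazol-5-yl in place of cyano on an aromatic carbon. Among the compounds with values here, no measured step exchanges a nitrile for a tetrazole, so the precedent is indirect. The steps of a 1.2-fold lower number from compound 1 to compound 2 (0.09 log units; within the scatter), a 1.3-fold lower number from compound 1 to compound 3 (0.12 log units; within the scatter) and a 1.1-fold lower number from compound 2 to compound 3 (0.03 log units; within the scatter) show that three different groups at this same aromatic carbon gave numbers that could not be told apart in this assay. On that basis a fourth group at the same place is expected to leave the number close to that of compound 3, with the tetrazole treated as a wider unknown. Compound 4 is therefore expected to show a 1.3-fold higher number from compound 3 to compound 4 (0.10 log units; within the scatter), with an estimate of 150 nM and a range from 50 nM to 450 nM.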

Compound 4, half-maximal inhibitory concentration: > 6000 nM
Compound 4: no number, only a limit (the forecaster's own chance of this, stated with the estimate: 5%); middle value at least 40-fold (1.60 log units) from the limit.
By their numbers in this assay, from the lowest: compounds 3, 2 and 1 (each within the scatter of the next). At a limit, above all of these: compound 4.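

In this assay compound 4 gave no number, only a limit: the limit of > 6000 nM in this assay, at which 1 of the 4 values shown sits.

The earlier compounds had shown methoxymethyl, acetyl and cyano at this aromatic carbon without a readable difference, but this position is not open to every group: 2H-tetrazol-5-yl gives an at least 50-fold higher number from compound 3 to compound 4 (1.69 log units; beyond the scatter), an at least 46-fold higher number from compound 2 to compound 4 (1.66 log units; beyond the scatter) and an at least 37-fold higher number from compound 1 to compound 4 (1.57 log units; beyond the scatter). Within the data shown here, the tolerance seen with compound 1, compound 2 and compound 3 therefore covers those three groups and does not extend to this five-membered aromatic ring, the only group here that brings a hydrogen-bond donor.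

The compounds shown do not separate the ring itself from that donor. As far as these compounds go, how a methyl-substituted tetrazole, a carboxylic acid or an amine would fare at this aromatic carbon also remains open.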